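Swapping tert-butyl for nitro on a cytotoxicity series

The compounds below may be only part of what the source reports. "The series", "measured", "known", "first", "only" and "open" are said of these compounds alone.

Of the compounds shown here, three of one shared core have been tested in an ADME assay on S2 cells (Drosophila melanogaster) for cytotoxicity, read by MTT assay; on this read-out lower numbers stand for an effect already at smaller amounts and higher numbers for an effect only at larger amounts of compound. Compound 1 `Cc1ccc(NC(=O)/C=C/[C@H]2C[C@@H](O)[C@@H](O)C2)cc1` reaches only the limit > 190000 nM. Compound 2 `COc1ccc(NC(=O)/C=C/[C@H]2C[C@@H](O)[C@@H](O)C2)cc1` likewise gives only the limit > 180000 nM. Compound 3 `CC(C)(C)c1ccc(NC(=O)/C=C/[C@H]2C[C@@H](O)[C@@H](O)C2)cc1` also stops at the limit > 180000 nM, so its position cannot be placed against the other two, which sit at the limit of > 180000 nM in this assay, at which 2 of the 3 values shown sit, and (the limit of > 190000 nM in this assay, at which 1 of the 3 values shown sits). The steps a step that the two limits leave unreadable from compound 1 to compound 3 and a step that the two limits leave unreadable from compound 2 to compound 3 are therefore unreadable, as is a step that the two limits leave unreadable from compound 1 to compound 2. Compound 4 `O=C(/C=C/[C@H]1C[C@@H](O)[C@@H](O)C1)Nc1ccc([N+](=O)[O-])cc1` differs from compound 3 by nitro in place of tert-butyl on an aromatic carbon. With no readable step to lean on, the expected step is a number no higher from compound 3 to compound 4 (the limit leaves the size open), no change beyond the scatter. Compound 4 is thus estimated at 180000 nM, within 60000 nM to 500000 nM, most likely again reported only as a limit.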

Compound 4, half-maximal effective concentration: > 170000 nM
Compound 4 was reported as a limit; the forecaster's own chance of this, stated with the estimate: 75%; the middle value is on the limit's open side.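

Compound 4 gives only a limit, > 170000 nM, so its steps from compound 1, compound 2 and compound 3 cannot be read. The compounds shown leave open whether methyl, methoxy, tert-butyl and nitro differ at all in this assay.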